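Adding a Second Hydroxy to the Fused Ring of Compound 2

The source may hold more compounds than are shown below. What is called first, only, known or untested is meant among the compounds shown, and "the series" means these compounds.

Measured so far:
compound 1 `O=c1cc(/C=C/c2ccccc2)oc2cc(O)cc(O)c12` gives 46600 nM
compound 2 `O=c1cc(/C=C/c2ccc(O)cc2)oc2cccc(O)c12` gives 1040 nM

Both compounds were tested in a functional assay, in the absence of a further agent; on this read-out higher numbers stand for weaker inhibition and lower numbers for stronger inhibition. Within the data shown here, on that read-out compound 2 stands lowest of the two numbers; compound 1 is the only neighbour, and its number is far higher than that of compound 2, a gap well beyond the usual scatter. The two compounds differ in more than one place, so this gap alone cannot be traced to a single change.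

The next compound, compound 3 `O=c1cc(/C=C/c2ccc(O)cc2)oc2cc(O)cc(O)c12`, is compound 2 with one change: hydroxy in place of hydrogen on an aromatic carbon. Among the measured compounds shown here, no comparable one-place step has been measured yet, so its size is open. Compound 1 already carries the same pair of hydroxy groups on its fused ring and gives 46600 nM, while compound 2, with one hydroxy on the fused ring and one on the outer ring, gives 1040 nM. Taken together these numbers leave room for a small to moderate shift in either direction, and a step toward a somewhat higher number seems the likelier outcome. Compound 3 is therefore expected to come out near 2500 nM, within a range of 500 nM to 12000 nM, which would mean an estimated step of a 2.4-fold higher number from compound 2 to compound 3 (0.38 log units; beyond the scatter).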

Compound 3, half-maximal inhibitory concentration: 1250 nM
Compound 3: the middle estimate sits 2.0-fold (0.30 log units) above what was measured; the measured number falls inside the stated range.
By their numbers in this assay, from the lowest: compounds 2 and 3 (each within the scatter of the next); then compound 1.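

In this assay, the step of a 1.2-fold higher number from compound 2 to compound 3 (0.08 log units; within the scatter) shows that a hydroxy can take the place of hydrogen at this carbon of the fused ring with no change that stands out from the usual scatter, so compound 2 and compound 3 cannot be ranked against each other. The same kind of swap on the outer ring, seen in the step of a 37-fold lower number from compound 1 to compound 3 (1.57 log units; beyond the scatter), is large, which shows that in this pair of steps the place of the new hydroxy matters far more than the simple fact of adding one. Nothing measured alongside these numbers explains either step.

On these data alone, what remains open is whether this carbon of the fused ring would accept groups other than hydroxy just as readily, such as a methoxy, an amine or a carboxylic acid, or whether a larger group would move the number beyond the scatter. As far as these compounds go, it is also open whether the large step on the outer ring would appear at the same size on a core with a different set of hydroxy groups on the fused ring.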